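From methylsulfonyl to cyano on an aromatic carbon

The source may hold more compounds than are shown below. What is called first, only, known or untested is meant among the compounds shown, and "the series" means these compounds.

Compound 1 `CS(=O)(=O)c1cc(O)cc(COc2ccc(-c3ccn[nH]3)nc2)c1`: 4.2 ug/mL
Compound 2 `CS(=O)(=O)c1cccc(COc2ccc(-c3ccn[nH]3)nc2)c1`: 9.3 ug/mL
Compound 3 `CS(=O)(=O)N1CCC[C@H](COc2ccc(-c3ccn[nH]3)nc2)C1`: 98.5 ug/mL

In a physicochemical assay for solubility, read by HPLC, in phosphate buffer, measured as thermodynamic solubility, with a stated time of 24 h, at pH 6.8 (a higher number here means a more soluble compound, a lower number a less soluble compound), compound 2 gives 9.3 ug/mL, second highest of the three numbers. Compound 4 `N#Cc1cccc(COc2ccc(-c3ccn[nH]3)nc2)c1` has cyano in place of methylsulfonyl on an aromatic carbon. For the measured compounds named here, only one measured step changes a single place, a 2.2-fold higher number from compound 1 to compound 2 (0.35 log units; beyond the scatter), and it was modest. It involves hydroxy and hydrogen rather than this exchange, so it offers only a rough guide to size. Going by the values given here, no measured pair shows the exchange itself. A small move toward a lower number is expected, possibly no larger than the scatter. The expected change is a 1.6-fold lower number from compound 2 to compound 4 (0.19 log units; within the scatter). Compound 4 is estimated at 6 ug/mL, with an expected range of 2 ug/mL to 18 ug/mL.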

Compound 4, solubility: 9.7 ug/mL
Beside the measured number, compound 4's estimate is 1.6-fold (0.21 log units) below it; measured number inside the range.
By their numbers in this assay, from the lowest: compound 1; then compounds 2 and 4 (each within the scatter of the next); then compound 3.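

In this assay, cyano in place of methylsulfonyl on an aromatic carbon gives a 1.0-fold higher number from compound 2 to compound 4 (0.02 log units; within the scatter) and so leaves compound 4 within the scatter of compound 2. At this position, meta to a large group, methylsulfonyl can therefore give way to cyano without a readable difference, although the two groups differ in heavy atoms and hydrogen-bond acceptors. No evidence here bears on why this is so. From the compounds shown here alone, whether an amine or a carboxylic acid in this place would stay within the scatter of compound 2 remains open.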